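Urea aryl swap on the quinoline amine series

A few compounds are considered here, and "the series" means these few. Any claim that something is new, unique, unknown or untested is made for them only; others in the source may bear on it.

Measured so far in a functional assay on HeLa cells (Homo sapiens) for inhibition, read by MTT assay, with a stated time of 72 h; a lower number here means a stronger inhibitor, a higher number a weaker inhibitor:
- compound 1 `COc1cc(NC(C)CCCNC(=O)Nc2cccc(Cl)c2)c2ncccc2c1`: 17000 nM
- compound 2 `COc1cc(NC(C)CCCNC(=O)Nc2cccc(C(F)(F)F)c2)c2ncccc2c1`: 14000 nM
- compound 3 `COc1cc(NC(C)CCCNC(=O)NNC(=O)Nc2ccc(O)cc2)c2ncccc2c1`: 85000 nM

Compound 1 sits second highest of the three numbers. Its nearest neighbour is compound 2, with a 1.2-fold lower number from compound 1 to compound 2 (0.08 log units; within the scatter), so the two are not separable here. The far end is compound 3, with a 5.0-fold higher number from compound 1 to compound 3 (0.70 log units; beyond the scatter) and, from the other side, a 6.1-fold higher number from compound 2 to compound 3 (0.78 log units; beyond the scatter).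

Compound 4 `COc1cc(NC(C)CCCNC(=O)Nc2ccc(O)cc2)c2ncccc2c1` is not yet measured. It differs from compound 1 by 4-hydroxyphenyl in place of 3-chlorophenyl on an amide-type nitrogen.

For the measured compounds named here, two measured steps bear on this. The step from compound 1 to compound 2 shows that exchanging one substituent on the aryl urea for another leaves the number within the scatter. The step from compound 1 to compound 3 introduces the 4-hydroxyphenyl together with the extra carbamoylamino link and gives a modest rise; the aryl change in compound 4 is only part of that change, with no new link inserted. The expected effect is therefore at most a modest rise in the number, smaller than a 5.0-fold higher number from compound 1 to compound 3 (0.70 log units; beyond the scatter), and possibly none beyond the scatter.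

Compound 4 is estimated at 30000 nM, between 12000 nM and 80000 nM, which is expected to correspond to a 1.8-fold higher number from compound 1 to compound 4 (0.25 log units; within the scatter).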

Compound 4, half-maximal inhibitory concentration: 70000 nM
For compound 4 the middle estimate is 2.3-fold (0.37 log units) below the measured one; measured number inside the range.
By their numbers in this assay, from the lowest: compounds 2 and 1 (each within the scatter of the next); then compounds 4 and 3 (each within the scatter of the next).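

In this assay, for the compounds shown here, the aryl group on the urea nitrogen matters even with no new link inserted: a 4.1-fold higher number from compound 1 to compound 4 (0.61 log units; beyond the scatter), and a 5.0-fold higher number from compound 2 to compound 4 (0.70 log units; beyond the scatter), whereas the exchange of chloro for trifluoromethyl in the earlier compounds gave no separable change. The step of a 1.2-fold lower number from compound 3 to compound 4 (0.08 log units; within the scatter) shows that, with 4-hydroxyphenyl present at the end of the chain, the added carbamoylamino link does not separate the two compounds, so the earlier rise seen with compound 3 can no longer be assigned to that link. No accompanying measurement bears on why the change from 3-chlorophenyl to 4-hydroxyphenyl raises the number.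

On these data alone, it remains open whether the rise follows the hydroxy group itself or the loss of the 3-chlorophenyl, and a plain phenyl, or a phenyl carrying an amine or a carboxylic acid in place of the hydroxy group, would help to separate these readings. As far as these compounds go, the effect of a longer chain between the urea and the shared core also remains open.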